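The source may hold more compounds than are shown below. What is called first, only, known or untested is meant among the compounds shown, and "the series" means these compounds.

The measured compounds, each in a functional assay on HeLa cells (Homo sapiens) for antiproliferative activity, read by CCK-8 assay, with a stated time of 72 h, tested at 8 uM; a higher number here means a stronger effect of the compound at the concentration tested, a lower number a weaker effect:
compound 1, `Nc1ccccc1NC(=O)c1ccc(CSC(=S)N2CCN(c3ccc(Cl)cc3)CC2)cc1`, gives 44.8%;
compound 2, `Nc1ccccc1NC(=O)c1ccc(CSC(=S)N2CCN(c3cccnc3)CC2)cc1`, gives 72.5%;
compound 3, `Cc1ccc(N2CCN(C(=S)SCc3ccc(C(=O)Nc4ccccc4N)cc3)CC2)cc1`, gives 24%.

All three share one core and differ only in the group on the amine nitrogen in the ring. Compound 3 stands lowest of the three: a number 20.8 percentage points lower from compound 1 to compound 3 (beyond the scatter), and a number 48.5 percentage points lower from compound 2 to compound 3 (beyond the scatter).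

Compound 4, `Nc1ccccc1NC(=O)c1ccc(CSC(=S)N2CCN(c3ccccc3F)CC2)cc1`, has not been measured yet. Its change from compound 3 is 2-fluorophenyl in place of 4-methylphenyl on an amine nitrogen in a ring.

Among the measured compounds shown here, the step that bears most on this is the one from compound 1 to compound 3, where methyl in place of chloro gave a number 20.8 percentage points lower from compound 1 to compound 3 (beyond the scatter). Compound 4 again carries a phenyl with a halogen rather than a methyl, though with fluorine in another place on the ring, so some of that lost ground may be regained. For the measured compounds named here, no measured pair shows exactly this change, so the expected step is modest rather than large: an increase from compound 3 to compound 4 of a number 16 percentage points higher from compound 3 to compound 4 (beyond the scatter) is expected. Compound 4 is therefore estimated at 40%, within a range from 24% to 58%.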

Compound 4, a percentage reported as inhibition, at one concentration (the size of the read-out at that concentration, not a potency): 59.2%
Beside the measured number, compound 4's estimate is 19.2 percentage points below it, and the stated range ends below it.
By their numbers in this assay, from the lowest: compound 3; then compound 1; then compound 4; then compound 2.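

Compound 4 shows that a ring of carbon only on the amine nitrogen in the ring can give a high number in this assay, so the low number of compound 3 does not hold for all such groups: the swap of 4-methylphenyl for 2-fluorophenyl gives a large rise (a number 35.2 percentage points higher from compound 3 to compound 4 (beyond the scatter)). The 2-fluorophenyl group also outdoes 4-chlorophenyl (a number 14.4 percentage points higher from compound 1 to compound 4 (beyond the scatter)), yet it still falls short of pyridin-3-yl (a number 13.3 percentage points lower from compound 2 to compound 4 (beyond the scatter)), so a halogen on the phenyl ring does not set one fixed level. No supporting information explains these differences.

From the compounds shown here alone, the 2-fluorophenyl and 4-chlorophenyl groups differ in both the halogen and its place on the ring, so the share of each remains open. Also open, going by these compounds, is how a phenyl ring bearing an amine or a carboxylic acid, or a pyridine ring bearing fluorine, would compare.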